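The source may hold more compounds than are shown below. What is called first, only, known or untested is meant among the compounds shown, and "the series" means these compounds.

The shared core appears first in compound 1 `C=C1CC[C@@H]2[C@](C)(CO)[C@H](O)CC[C@@]2(C)[C@@H]1CCC1=CCOC1=O`; in a functional assay on MDA-MB-231 cells (Homo sapiens) for cytotoxicity, read by MTT assay, with a stated time of 48 h (a lower number here means a stronger inhibitor, a higher number a weaker inhibitor), compound 1 gives "not active" (no number reported). Compound 2 `C=C1CC[C@@H]2[C@](C)(CO)[C@H](O)CC[C@@]2(C)[C@@H]1CCc1ccoc1` reaches only the limit of this assay, > 100000 nM, so no number is known for it. It thus sits at the limit of > 100000 nM in this assay, at which 1 of the 3 values shown sits. Compound 3 `C=C1CC[C@@H]2[C@](C)(COC(=O)C(Cl)Cl)[C@H](OC(=O)C(Cl)Cl)CC[C@@]2(C)[C@@H]1CCc1ccoc1` gives 2640 nM in this assay. Compound 4 `C=C1CC[C@@H]2[C@](C)(COC(=O)c3ccc([N+](=O)[O-])cc3)[C@H](O)CC[C@@]2(C)[C@@H]1CCc1ccoc1` differs from compound 2 by (4-nitrophenyl)carbonyl in place of hydrogen on an oxygen on a saturated carbon. Among the compounds with values here, no measured step between two compounds differing in one place exists here, so the size of that change is not known from the data. Because compound 3 gives 2640 nM in this assay, compound 4 is expected to give 15000 nM, within 3000 nM to 100000 nM. The expected step of an at least 6.6-fold lower number from compound 2 to compound 4 (0.82 log units; beyond the scatter) is a gain beyond the scatter.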

Compound 4, half-maximal inhibitory concentration: 37500 nM
For compound 4 the middle estimate is 2.5-fold (0.40 log units) below the measured one, within the range that was stated.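

In this assay, within the data shown here, (4-nitrophenyl)carbonyl in place of hydrogen on an oxygen on a saturated carbon gives an at least 2.6-fold lower number from compound 2 to compound 4 (0.42 log units; beyond the scatter), the first step at this position that can be read. One change at this oxygen is thus enough to give a measurable number, while the other hydroxyl of compound 4 stays free. The true size of the step remains unknown, since compound 2 stands only at a limit: the limit of > 100000 nM in this assay, at which 1 of the 4 values shown sits.

Going by these compounds, it remains open whether a simple acetyl group or a longer chain at this oxygen would give a similar step. On these data alone, it is also open whether an amine on the aromatic ring in place of the nitro group would keep it.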